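From Cyclobutyl to Benzyl on an Aromatic Nitrogen

The source may hold more compounds than are shown below. What is called first, only, known or untested is meant among the compounds shown, and "the series" means these compounds.

Compound 1 `CCn1nc(C(=O)N[C@H]2COc3ccccc3N(C)C2=S)nc1Cc1ccccc1` — in a toxicity assay on HT-29 cells (Homo sapiens) for cytotoxicity (on this read-out higher numbers stand for lower toxicity in this test and lower numbers for higher toxicity in this test), compound 1 gives > 100000 nM, a limit of the assay rather than a number.
Compound 2 `CC(C)CCn1nc(C(=O)N[C@H]2COc3ccccc3N(C)C2=S)nc1Cc1ccccc1` — in this assay compound 2 gives > 100000 nM, again a limit.
Compound 3 `CN1C(=S)[C@@H](NC(=O)c2nc(Cc3ccccc3)n(C3CCC3)n2)COc2ccccc21` — in this assay compound 3 gives > 100000 nM, also a limit.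

All three measured compounds share the same core and differ only in the group carried on one aromatic nitrogen, and all three sit at the same point, (the limit of > 100000 nM in this assay, at which 3 of the 3 values shown sit). Because of the limit of > 100000 nM in this assay, at which 3 of the 3 values shown sit, none of the changes between them can be read as a step of any size: a step that the two limits leave unreadable from compound 1 to compound 2, a step that the two limits leave unreadable from compound 1 to compound 3 and a step that the two limits leave unreadable from compound 2 to compound 3 are all left open by the two limits. Compound 3 therefore stands at a limit, with no number of its own and no neighbour that gives one.

Compound 4 `CN1C(=S)[C@@H](NC(=O)c2nc(Cc3ccccc3)n(Cc3ccccc3)n2)COc2ccccc21` is the next compound, differing from compound 3 in one place: benzyl in place of cyclobutyl on an aromatic nitrogen. Within the data shown here, no measured step bears on this change, since every comparison available ends at the limit. The expectation for compound 4 is therefore that it behaves like the others and that a number no higher from compound 3 to compound 4 (the limit leaves the size open) shows no readable step. Compound 4 is estimated at 100000 nM, within a range from 30000 nM to 1000000 nM.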

Compound 4, half-maximal cytotoxic concentration: > 100000 nM
Compound 4: only a limit was reported; the forecaster's own chance of this, stated with the estimate: 80%; the middle value lies on the limit itself.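

In this assay compound 4 gives > 100000 nM, a limit of the assay and not a number. Its steps from compound 1, compound 2 and compound 3 therefore cannot be read: the limit of > 100000 nM in this assay, at which 4 of the 4 values shown sit. The compounds shown leave open whether changing the group on this aromatic nitrogen alters toxicity in these cells at all, and by how much.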